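The source may hold more compounds than are shown below. What is called first, only, known or untested is meant among the compounds shown, and "the series" means these compounds.

Compound 1 `COc1cccc(/C=C/C(=O)c2ccc(OC)c3c2OC(C)(C)C=C3)c1`: > 10000 nM
Compound 2 `COc1ccc(C(=O)/C=C/c2ccc3ccccc3c2)c2c1C=CC(C)(C)O2`: 2140 nM
Compound 3 `COc1ccc(C(=O)/C=C/c2ccc(-n3ccnc3)cc2)c2c1C=CC(C)(C)O2`: > 10000 nM

All three share one core and differ only in the aromatic group on the double-bonded chain. In a functional assay on SW-620 cells (Homo sapiens) for antiproliferative activity, read by MTT assay, with a stated time of 24 h (a lower number here means a stronger inhibitor, a higher number a weaker inhibitor), compound 1 returns only a limit, > 10000 nM, not a number. Compound 1 thus sits at the limit of > 10000 nM in this assay, at which 2 of the 3 values shown sit. Compound 2 gives a number, 2140 nM. Compound 3 again reaches only a limit, > 10000 nM. Going by the values given here, no step between measured compounds has been worked out, so only the values themselves can be set side by side.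

Compound 4 `COc1ccc(C(=O)/C=C/c2ccccn2)c2c1C=CC(C)(C)O2` is not yet measured. It differs from compound 1 as follows: pyridin-2-yl in place of 3-methoxyphenyl on a double-bonded chain carbon bound to a double-bonded chain carbon

Because compound 1 is known only as a limit, > 10000 nM, no firm direction can be read off. Compound 4 is expected near 9000 nM, within 3000 nM to 30000 nM, and may well again yield only a limit. The expected step is an at least 1.1-fold lower number from compound 1 to compound 4 (0.04 log units; that floor lies within the scatter), no more than the scatter.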

Compound 4, half-maximal inhibitory concentration: 5000 nM
Estimate against measurement, compound 4: 1.8-fold (0.26 log units) above; the measured number falls inside the stated range.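

The step from the 3-methoxyphenyl to the pyridin-2-yl group is an at least 2.0-fold lower number from compound 1 to compound 4 (0.30 log units; that floor lies within the scatter). This shows that a carbon-only ring with a methoxy group can give way at this chain carbon to a smaller ring holding a nitrogen, and the compound still gives a true number in this assay. Compound 1 is only a limit, so the step has a floor but no known size: the limit of > 10000 nM in this assay, at which 2 of the 4 values shown sit.

On these data alone, what remains open is whether the ring nitrogen or the loss of the methoxy group accounts for the step. An unsubstituted phenyl or a pyridin-3-yl group at this place would help separate the two.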